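The compounds below may be only part of what the source reports. "The series", "measured", "known", "first", "only" and "open" are said of these compounds alone.

Compound 3 `O=C(c1cc(-c2ccc(Cl)cc2Cl)n[nH]1)N1CCCCCC1` stands with the highest number of the three measured: in an assay on isolated protein for inhibition of alkaline phosphatase, tissue-nonspecific isozyme (Homo sapiens) (on this read-out lower numbers stand for stronger inhibition and higher numbers for weaker inhibition), compound 3 gives 1450 nM. Compound 1 `CC(C)NC(=O)c1cc(-c2ccc(Cl)cc2Cl)n[nH]1` gives 51 nM and compound 2 `CN1CCN(C(=O)c2cc(-c3ccc(Cl)cc3Cl)n[nH]2)CC1` gives 828 nM. The change from compound 3 to compound 4 `O=C(NCCCCO)c1cc(-c2ccc(Cl)cc2Cl)n[nH]1` is (4-hydroxybutyl)amino in place of azepan-1-yl on a carbonyl carbon. The measured steps that bear on it are a 28-fold higher number from compound 1 to compound 3 (1.45 log units; beyond the scatter) and a 16-fold higher number from compound 1 to compound 2 (1.21 log units; beyond the scatter), both large, whereas a 1.8-fold higher number from compound 2 to compound 3 (0.24 log units; within the scatter). Compound 4 again carries an open-chain amino group on the carbonyl carbon, as compound 1 does, so a large step down in this assay is expected, recovering much of a 28-fold higher number from compound 1 to compound 3 (1.45 log units; beyond the scatter). For compound 4 the expected value is 100 nM, in an expected range of 30 nM to 400 nM. The expected step is a 15-fold lower number from compound 3 to compound 4 (1.16 log units; beyond the scatter).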

Compound 4, half-maximal inhibitory concentration: 35 nM
For compound 4 the middle estimate is 2.9-fold (0.46 log units) above the measured one, and the stated range covers the measured number.
By their numbers in this assay, from the lowest: compounds 4 and 1 (each within the scatter of the next); then compounds 2 and 3 (each within the scatter of the next).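

In this assay, the open-chain (4-hydroxybutyl)amino group separates clearly from both ring amines, azepan-1-yl (a 41-fold lower number from compound 3 to compound 4 (1.62 log units; beyond the scatter)) and 4-methylpiperazin-1-yl (a 24-fold lower number from compound 2 to compound 4 (1.37 log units; beyond the scatter)), while on the amide-type nitrogen 4-hydroxybutyl and isopropyl remain indistinguishable (a 1.5-fold lower number from compound 1 to compound 4 (0.16 log units; within the scatter)). Across these four compounds, both open-chain groups give low numbers and both ring amines give high numbers, with no exception. No measurement shown accounts for this split.

Open, going by these compounds, is whether a plain butylamino group, lacking the hydroxyl, would match compound 4. Also open, on these data alone, is where a dimethylamino group, open-chain but without the amide hydrogen, would fall.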